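Cyano for methoxy on the thiourea aryl of compound 1

The source may hold more compounds than are shown below. What is called first, only, known or untested is meant among the compounds shown, and "the series" means these compounds.

Measured compounds and their values:
compound 1, `COc1cccc(NC(=S)NC2CC(C)(C)Oc3ccc(Br)cc32)c1`: 66000 nM
compound 2, `CCOC(=O)NC1CC(C)(C)Oc2ccc(Cl)cc21`: > 100000 nM
compound 3, `CC1(C)CC(NC(=S)Nc2ccc([N+](=O)[O-])cc2)c2cc(Br)ccc2O1`: 9000 nM

In a functional assay on U-373MG ATCC cells (Homo sapiens) for inhibition, read by MTT assay, with a stated time of 72 h (a higher number here means a weaker inhibitor, a lower number a stronger inhibitor), compound 1 gives 66000 nM, the higher of the two numbers reported. Compound 3 gives 9000 nM in this assay, a lower number, and the gap between the two lies beyond the usual scatter. Compound 2 is reported in this assay only as a limit, > 100000 nM, with no number behind it. Among these three, compound 1 stands at the weak end of what was measured.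

The compound not yet measured, compound 4, `CC1(C)CC(NC(=S)Nc2cccc(C#N)c2)c2cc(Br)ccc2O1`, keeps the shared core and thiourea of compound 1 and differs in one place: cyano in place of methoxy on an aromatic carbon The same difference, read one bond further out, is 3-methoxyphenyl to 3-cyanophenyl.

Among the measured compounds shown here, no step between measured compounds isolates this change, so the size of the expected step rests on compound 1 alone. Compound 4 is expected to give a somewhat lower number than compound 1, a step of a 1.9-fold lower number from compound 1 to compound 4 (0.28 log units; within the scatter), modest and close to the edge of the scatter. For compound 4 the estimate in this assay is 35000 nM, with a range from 8000 nM to 120000 nM.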

Compound 4, half-maximal inhibitory concentration: 6000 nM
Compound 4: the middle estimate sits 5.8-fold (0.77 log units) above what was measured; measured number outside the range, below it.
By their numbers in this assay, from the lowest: compounds 4 and 3 (each within the scatter of the next); then compound 1. At a limit, above all of these: compound 2.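

In this assay, among the compounds shown here, the change of cyano in place of methoxy, on an aromatic carbon meta to a large group, gives an 11-fold lower number from compound 1 to compound 4 (1.04 log units; beyond the scatter) and is the first change at this place on the thiourea aryl that can be read on its own. This place is therefore not indifferent to what it carries: the two groups match in their count of heavy atoms and of hydrogen-bond acceptors, and neither brings a ring or a net charge, yet the step lies well beyond the scatter, so those counts alone do not set the number here. What it is about the nitrile that goes with this step is not told by any measurement at hand.

As far as these compounds go, from this single pair it remains open whether the step belongs to the nitrile itself or would also appear with other groups on this carbon, such as an amine, a carboxylic acid or a trifluoromethyl group. Also open, from the compounds shown here alone, is whether the same change would give a step of this size with chloro in place of bromo on the shared core.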